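Dipropylamino to dipentylamino: expected step in the series

The source may report more compounds than this note shows. Statements on the series, on what has been measured and on what is new or still open speak of the compounds shown alone.

In a functional assay on LNCaP cells (Homo sapiens) for antiproliferative activity, read by WST assay, with a stated time of 3 days (on this read-out lower numbers stand for stronger inhibition and higher numbers for weaker inhibition), compound 1 `CCCOc1c(-c2cc(OC)c(OC)c(OC)c2)oc2ccccc2c1=O` gives 5700 nM and compound 2 `CCCCCOc1c(-c2cc(OC)c(OC)c(OC)c2)oc2ccccc2c1=O` gives 15400 nM. Compound 3 `CCCN(CCC)CCCCOc1c(-c2cc(OC)c(OC)c(OC)c2)oc2ccccc2c1=O` gives 16800 nM, the highest of the three numbers, but a 1.1-fold higher number from compound 2 to compound 3 (0.04 log units; within the scatter) does not separate it from compound 2. Only compound 1 stands clearly lower, as shown by a 2.9-fold higher number from compound 1 to compound 3 (0.47 log units; beyond the scatter).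

Compound 4 `CCCCCN(CCCCC)CCCCOc1c(-c2cc(OC)c(OC)c(OC)c2)oc2ccccc2c1=O` carries dipentylamino in place of dipropylamino on a saturated chain carbon, four bonds along the chain from an oxygen on an aromatic ring. For the measured compounds named here, no measured step makes this exact change. The closest evidence is limited: a 2.7-fold higher number from compound 1 to compound 2 (0.43 log units; beyond the scatter) was modest, and a 1.1-fold higher number from compound 2 to compound 3 (0.04 log units; within the scatter), with dipropylamino in place of methyl, stayed within the scatter. A small step in this assay is therefore expected, possibly none beyond the scatter, and without a firm direction. The expected change is a 1.1-fold lower number from compound 3 to compound 4 (0.05 log units; within the scatter). Compound 4 is estimated at 15000 nM, with an expected range of 6000 nM to 38000 nM.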

Compound 4, half-maximal inhibitory concentration: 9700 nM
Compound 4: the middle estimate sits 1.5-fold (0.19 log units) above what was measured; the range from low to high includes it.
By their numbers in this assay, from the lowest: compounds 1, 4, 2 and 3 (each within the scatter of the next, the first and the last beyond it).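

In this assay, dipentylamino in place of dipropylamino on a saturated chain carbon, four bonds along the chain from an oxygen on an aromatic ring, gives a 1.7-fold lower number from compound 3 to compound 4 (0.24 log units; within the scatter) and so shows that this place accepts the larger amine without a step beyond the scatter. Compound 4 also shows a 1.6-fold lower number from compound 2 to compound 4 (0.20 log units; within the scatter) and a 1.7-fold higher number from compound 1 to compound 4 (0.23 log units; within the scatter) while compound 3 shows a 2.9-fold higher number from compound 1 to compound 3 (0.47 log units; beyond the scatter) so a dialkylamino group here does not by itself set a compound apart from compound 1, with compound 3 as the one case that stands apart. Nothing measured here accounts for these numbers.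

Still open, going by these compounds, is how a piperidine or morpholine ring would read in place of the dialkylamino group. Also open, on these data alone, is whether a dioctylamino group would stay within the scatter of compound 4.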